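This account rests on a few compounds, and the source may have more. Where it says the series, first, only, none or still open, it means among the compounds named here.

In a functional assay on blood for antagonist activity at thromboxane A2 receptor (Homo sapiens) (a higher number here means weaker binding, a lower number tighter binding), compound 1 `O=C(O)CC/C=C\CO[C@H]1C(OCc2ccc(-c3ccc(CO)cc3)cc2)CC[C@@H]1N1CCCCCC1` gives 3.16 nM, the lower of the two numbers seen so far; compound 2 `O=C(O)CC/C=C\CO[C@H]1[C@@H](OCc2ccc(-c3ccc(CO)cc3)cc2)CC[C@@H]1N1CCCCCC1` gives 3.98 nM, and the step of a 1.3-fold higher number from compound 1 to compound 2 (0.10 log units; within the scatter) lies within the scatter. Compound 3 `NC(=O)Cc1ccccc1-c1ccc(COC2CC[C@H](N3CCCCCC3)[C@H]2OC/C=C\CCC(=O)O)cc1` differs from compound 1 by a group of 10 heavy atoms (8 carbon, 1 nitrogen, 1 oxygen; one six-membered aromatic ring of carbon only) in place of a group of 8 heavy atoms (7 carbon, 1 oxygen; one six-membered aromatic ring of carbon only), on an aromatic carbon. Among the measured compounds shown here, the only measured step concerns a stereocentre drawn with or without a configuration, as noted in the fact that one of compounds 1 and 2 is drawn with a defined configuration and the other without, at the place where they differ, and does not bear on this replacement. For the measured compounds named here, with no comparable step to lean on, the estimate for compound 3 is 3.5 nM, within the range 1 nM to 12 nM, which means an expected step of a 1.1-fold higher number from compound 1 to compound 3 (0.04 log units; within the scatter) of no size beyond the scatter.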

Compound 3, dissociation constant: 7.94 nM
Estimate against measurement, compound 3: 2.3-fold (0.36 log units) below; low and high end bracket the measured number.
By their numbers in this assay, from the lowest: compounds 1, 2 and 3 (each within the scatter of the next, the first and the last beyond it).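

In this assay, putting the larger nitrogen-bearing group in place of 4-(hydroxymethyl)phenyl, on an aromatic carbon para to a large group, gives a 2.5-fold higher number from compound 1 to compound 3 (0.40 log units; beyond the scatter) and so shows that this position responds to the change, if only modestly. Both groups have the same counts of hydrogen-bond donors and acceptors, so those counts do not separate them. Nothing at hand bears on what lies behind this step. From the compounds shown here alone, it remains open which part of the entering group matters, and how a carboxylic acid or a simple amine at this position would compare.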